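Replacing phenyl on a saturated ring carbon

The source may report more compounds than this note shows. Statements on the series, on what has been measured and on what is new or still open speak of the compounds shown alone.

- compound 1 `CC(=O)N1N=C(Nc2nc3ccc(C)cc3s2)CC1OC1=CC=C1` gives 160 umol/kg in a functional assay on the whole organism (Hindlimb, strain albino) with Mus musculus as the target, in the maximal electroshock model, with a stated time of 0.5 h; a lower number here means that less compound is needed, a higher number that more compound is needed for the effect
- compound 2 `CC(=O)N1N=C(Nc2nc3ccc([N+](=O)[O-])cc3s2)CC1c1ccccc1` gives 216 umol/kg in this assay

On these two numbers, compound 2 lies within the usual scatter of compound 1, so this assay does not separate them. The open question is compound 3 `CC(=O)N1N=C(Nc2nc3ccc([N+](=O)[O-])cc3s2)CC1OC1=CC=C1`, which keeps the core of compound 2 and changes one group. The change is a group of 5 heavy atoms (4 carbon, 1 oxygen; one four-membered non-aromatic ring of carbon only) in place of a group of 6 heavy atoms (6 carbon; one six-membered aromatic ring of carbon only), on a saturated ring carbon and nothing else differs between the two structures. Going by the values given here, no measured pair isolates this change, so the series offers no direct precedent for its size. Compound 1 carries the same entering group on a core that differs elsewhere. The expectation of a small step in this assay rests on compound 1 at 160 umol/kg and compound 2 at 216 umol/kg, two values within scatter of each other. The expected step of a 1.2-fold lower number from compound 2 to compound 3 (0.07 log units; within the scatter) therefore stays small and has no firm direction. Compound 3 is estimated at 185 umol/kg with an expected range of 95 umol/kg to 360 umol/kg for this compound.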

Compound 3, dose for half-maximal effect: 274 umol/kg
Compound 3: middle estimate off by 1.5-fold (0.17 log units), on the low side; the range from low to high includes it.
By their numbers in this assay, from the lowest: compounds 1, 2 and 3 (each within the scatter of the next).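

With the direct pair now in hand, this assay does not separate the two groups on the saturated ring carbon: the group with the four-membered non-aromatic ring and its oxygen, in place of phenyl, gives a 1.3-fold higher number from compound 2 to compound 3 (0.10 log units; within the scatter) and so, on the core of compound 2, this position tolerates the exchange without a step that can be read beyond the scatter. The entering group also gains a second reading on a different core, where nitro in place of methyl on an aromatic carbon gives a 1.7-fold higher number from compound 1 to compound 3 (0.23 log units; within the scatter) and so the aromatic position, with these two groups, is not separated either. Nothing measured alongside these numbers bears on why the three compounds lie so close together.

As far as these compounds go, how phenyl on the saturated ring carbon would read on the core of compound 1 stays open, and with it whether the two exchanges act independently of each other. Also open, from the compounds shown here alone, is whether a group of another kind at this carbon, such as an amine, a carboxylic acid or a longer chain, would give a step beyond the scatter.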